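Compound 2 to compound 3: hydrogen in place of chloro

This account rests on a few compounds, and the source may have more. Where it says the series, first, only, none or still open, it means among the compounds named here.

Compound 1 (`CCCCn1cnc2c(Nc3ccc(Cl)cc3)nc(N[C@H]3CC[C@H](N)CC3)nc21`) and compound 2 (`CCCCn1cnc2c(Nc3cccc(Cl)c3)nc(N[C@H]3CC[C@H](N)CC3)nc21`) share a core and differ only in the chlorophenyl group. In a functional assay on HCC827 cells (Homo sapiens) for inhibition, read by fluorescence, with a stated time of 72 h (a lower number here means a stronger inhibitor of growth, a higher number a weaker inhibitor of growth), compound 1 gives 10800 nM and compound 2 gives 7200 nM. Compound 2 therefore stands level with compound 1 within the scatter, and these two values are the only reference points so far.

Compound 3 (`CCCCn1cnc2c(Nc3ccccc3)nc(N[C@H]3CC[C@H](N)CC3)nc21`) differs from compound 2 by hydrogen in place of chloro on an aromatic carbon, turning 3-chlorophenyl into phenyl. Among the measured compounds shown here, the one measured step that bears on this is a 1.5-fold lower number from compound 1 to compound 2 (0.18 log units; within the scatter), with 3-chlorophenyl in place of 4-chlorophenyl. That step relocates the chloro without removing it, so it offers only indirect guidance. For the measured compounds named here, no measured compound lacks the chloro. With nothing pointing either way, no step beyond the scatter is expected in this assay, though the range is kept wide. The expected step is a 1.4-fold higher number from compound 2 to compound 3 (0.14 log units; within the scatter). For compound 3 the estimate is 10000 nM, with an expected range of 4000 nM to 22000 nM.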

Compound 3, concentration for 50% growth inhibition: 9000 nM
For compound 3 the middle estimate is 1.1-fold (0.05 log units) above the measured one, within the range that was stated.
By their numbers in this assay, from the lowest: compounds 2, 3 and 1 (each within the scatter of the next).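

In this assay, hydrogen in place of chloro reads as a 1.3-fold higher number from compound 2 to compound 3 (0.10 log units; within the scatter) on the 3-chlorophenyl side, and the same exchange reads as a 1.2-fold lower number from compound 1 to compound 3 (0.08 log units; within the scatter) on the 4-chlorophenyl side. The earlier pair only moved the chloro around the ring, whereas these two steps test its absence, and both stay within the scatter, so the chloro at either position makes no readable difference to the growth inhibition of this series: the plain phenyl of compound 3 stands level with both chlorinated compounds. No measurement is available that would account for this flat result.

Still open, on these data alone, is whether any other group on this aromatic ring would move the number beyond the scatter, for example a carboxylic acid, an amine, a methoxy group or a trifluoromethyl group in place of the hydrogen of compound 3. Also open, as far as these compounds go, is whether changes away from the anilino group, such as a longer chain in place of the butyl chain on the shared core, would carry more weight than the anilino substituents compared here.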